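Shortening a Side Chain in a Series Without Measurable Activity

This account rests on a few compounds, and the source may have more. Where it says the series, first, only, none or still open, it means among the compounds named here.

Three measured compounds make up this small set, and none of them gives a number. Compound 1 `CCC(C)C1NC(=O)N(C2CCCCC2)C1=O` carries a sec-butyl group and a cyclohexyl ring. In a functional assay on WI-38 cells (Homo sapiens) for inhibition (a lower number here means a stronger inhibitor, a higher number a weaker inhibitor), compound 1 gives > 100000 nM, which is a limit of the assay rather than a measured value. Compound 3 `CC(C)C1NC(=O)N(C2CCCC2)C1=O` carries an isopropyl group and a cyclopentyl ring on the same core. In this assay compound 3 likewise reaches only a limit, > 100000 nM. Compound 2 `CC(C)C(NC(=O)NO)C(=O)NC1CCCC1` is an open-chain relative. In this assay compound 2 also gives just a limit, > 100000 nM. Compound 1 thus stands exactly where the whole set stands: the limit of > 100000 nM in this assay, at which 3 of the 3 values shown sit. Within the data shown here, no step between measured compounds is available to show how large any change can be.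

Compound 4 `CC(C)C1NC(=O)N(C2CCCCC2)C1=O` differs from compound 1 by a single change: hydrogen in place of methyl on a saturated chain carbon, two bonds along the chain from a saturated ring carbon. Compound 3, which carries the same isopropyl group, sits at the limit > 100000 nM, so no step beyond the scatter is expected. Compound 4 is expected to give about 150000 nM, within 30000 nM to 1000000 nM, most likely again reported only as a limit. That estimate means a step that the limit leaves unreadable from compound 1 to compound 4 of no real size.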

Compound 4, half-maximal inhibitory concentration: > 100000 nM
Compound 4 ended at the assay's limit; the forecaster's own chance of this, stated with the estimate: 90%; the middle value does not contradict the limit.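

Compound 1 and compound 4 both end at a limit in this assay and so the size of the step between them cannot be read, which leaves the set where it stood: the limit of > 100000 nM in this assay, at which 4 of the 4 values shown sit. What the compounds shown leave open is whether any compound on this shared core gives a real number in this assay and which change would bring that about.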